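A Nitro-to-Hydroxy Swap Repeated on a Second Core

This account rests on a few compounds, and the source may have more. Where it says the series, first, only, none or still open, it means among the compounds named here.

Compound 1 `COc1cc(/C=C/C(=O)/C=C/c2nc3cc([N+](=O)[O-])ccc3n2C)ccc1O` and compound 2 `COc1cc(/C=C/C(=O)/C=C/c2nc3cc(O)ccc3n2C)ccc1O` differ in a single group: hydroxy in place of nitro on an aromatic carbon. In a functional assay on MCF7 cells (Homo sapiens) for cytotoxicity, read by MTT assay, with a stated time of 48 h (on this read-out higher numbers stand for weaker inhibition and lower numbers for stronger inhibition), compound 1 gives 3700 nM and compound 2 gives 2900 nM, a change of a 1.3-fold lower number from compound 1 to compound 2 (0.11 log units; within the scatter). Compound 3 `COc1ccc(/C=C/C(=O)/C=C/c2nc3cc([N+](=O)[O-])ccc3n2C)cc1O` carries a different core; how its core differs from that of compound 1 is counted as 3-hydroxy-4-methoxyphenyl in place of 4-hydroxy-3-methoxyphenyl on a double-bonded chain carbon bound to a double-bonded chain carbon, and in this assay compound 3 gives 4800 nM, a step of a 1.3-fold higher number from compound 1 to compound 3 (0.11 log units; within the scatter). Compound 4 `COc1ccc(/C=C/C(=O)/C=C/c2nc3cc(O)ccc3n2C)cc1O` has not yet been measured. It stands to compound 3 as compound 2 stands to compound 1: hydroxy in place of nitro on an aromatic carbon, the same change at the same place, made twice among these compounds. Because the earlier step was a 1.3-fold lower number from compound 1 to compound 2 (0.11 log units; within the scatter), the corresponding step is expected to be a 1.3-fold lower number from compound 3 to compound 4 (0.11 log units; within the scatter), resting on that single precedent. Compound 4 is therefore expected to give about 3700 nM, with a likely range from 1800 nM to 7500 nM.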

Compound 4, half-maximal inhibitory concentration: 1900 nM
The estimate for compound 4 lay 1.9-fold (0.29 log units) above the measured number; measured number inside the range.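

In this assay, hydroxy in place of nitro on the second core gives a 2.5-fold lower number from compound 3 to compound 4 (0.40 log units; beyond the scatter), a step that on its own lies beyond the scatter. Set beside the earlier case, the two steps cannot be told apart: the same change on two cores in this assay, a 1.3-fold lower number (0.11 log units; within the scatter) from compound 1 to compound 2 and a 2.5-fold lower number (0.40 log units; beyond the scatter) from compound 3 to compound 4, 2.0-fold (0.30 log units) apart, within the scatter of two such steps. The change therefore carried from one core to the other without a detectable difference in size, but two pairs in a single cell assay establish no general rule and do not explain the result.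

The compounds shown leave open how an amine or a carboxylic acid on the same aromatic carbon would compare with nitro and hydroxy. They also leave open whether the swap would behave alike on any further core.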